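A few compounds are considered here, and "the series" means these few. Any claim that something is new, unique, unknown or untested is made for them only; others in the source may bear on it.

The measured compounds:

Compound 1, `Cc1cc(C)c(Oc2cc(Nc3ccc(C#N)cc3)ncc2C(=O)NCc2cn(Cc3ccc(F)cc3)nn2)c(C)c1` — in an ADME assay on MT4 cells (Homo sapiens) for cytotoxicity, read by MTT assay, with a stated time of 5 days (on this read-out higher numbers stand for lower toxicity in this test and lower numbers for higher toxicity in this test), compound 1 gives >= 153000 nM, which is a limit of the assay, not a number.
Compound 2, `Cc1cc(C)c(Oc2cc(Nc3ccc(C#N)cc3)ncc2C(=O)NCc2cn(Cc3ccccc3C)nn2)c(C)c1` — in this assay compound 2 gives >= 164000 nM, again a limit.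
Compound 3, `Cc1cc(C)c(Oc2cc(Nc3ccc(C#N)cc3)ncc2C(=O)NCc2cn(Cc3ccccc3[N+](=O)[O-])nn2)c(C)c1` — in this assay compound 3 gives > 212000 nM, also a limit.

Compound 3 therefore stands at a limit, as do the two other values shown, so no ordering among the three can be read. The steps between them confirm this: a step that the two limits leave unreadable from compound 1 to compound 2, a step that the two limits leave unreadable from compound 1 to compound 3 and a step that the two limits leave unreadable from compound 2 to compound 3 are all unreadable, since each end sits at a limit (the limit of > 212000 nM in this assay, at which 1 of the 3 values shown sits, (the limit of >= 153000 nM in this assay, at which 1 of the 3 values shown sits), (the limit of >= 164000 nM in this assay, at which 1 of the 3 values shown sits)).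

The new compound 4, `Cc1cc(C)c(Oc2cc(Nc3ccc(C#N)cc3)ncc2C(=O)NCc2cn(Cc3cccc(C#N)c3)nn2)c(C)c1`, differs from compound 3 by 3-cyanophenyl in place of 2-nitrophenyl on a saturated chain carbon bound to an aromatic nitrogen. All three measured steps bear on the change at this position, and none of them shows any movement that the limits would let one see. Compound 4 is therefore expected to sit at a limit as well, with an estimated value of 180000 nM and a range from 100000 nM to 260000 nM. The step this estimate implies, an at least 1.1-fold lower number from compound 3 to compound 4 (0.07 log units; that floor lies within the scatter), is expected to be nothing beyond the scatter.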

Compound 4, half-maximal cytotoxic concentration: >= 129000 nM
Compound 4: no number, only a limit; the forecaster's own chance of this, stated with the estimate: 80%; the middle value is on the limit's open side.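

In this assay compound 4 gives >= 129000 nM, which is a limit of the assay and not a number. The steps to compound 4 from compound 1, compound 2 and compound 3 all join limits, so no new step can be read. The compounds shown leave open where the actual half-maximal cytotoxic concentration of each lies, and whether changing the group at this position moves it at all.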